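Swapping the Amide Aryl Ring on a Shared Chromone Core

A few compounds are considered here, and "the series" means these few. Any claim that something is new, unique, unknown or untested is made for them only; others in the source may bear on it.

Compound 3 `O=C(Nc1cccc(-c2oc3cc(-c4ccc(F)cc4)ccc3c(=O)c2O)c1)c1ccc(Cl)nc1` carries a 6-chloropyridin-3-yl group on the carbonyl carbon of its amide. In a functional assay on A549 cells (Homo sapiens) for antiproliferative activity, read by CCK-8 assay, with a stated time of 72 h (on this read-out higher numbers stand for weaker inhibition and lower numbers for stronger inhibition), compound 3 gives 3580 nM, the second highest of the three numbers measured. Its nearest neighbour is compound 2 `COc1cc(OC)cc(C(=O)Nc2cccc(-c3oc4cc(-c5ccc(F)cc5)ccc4c(=O)c3O)c2)c1`, which in this assay gives 2390 nM; the step of a 1.5-fold higher number from compound 2 to compound 3 (0.18 log units; within the scatter) lies within the scatter. Compound 1 `COc1ccc(C(=O)Nc2cccc(-c3oc4cc(-c5ccc(F)cc5)ccc4c(=O)c3O)c2)cc1` gives 8700 nM in this assay, and the step of a 2.4-fold lower number from compound 1 to compound 3 (0.39 log units; beyond the scatter) is beyond the scatter, as is a 3.6-fold lower number from compound 1 to compound 2 (0.56 log units; beyond the scatter). All three steps change only the aryl group on the carbonyl carbon, and the two beyond the scatter are modest.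

Compound 4 `O=C(Nc1cccc(-c2oc3cc(-c4ccc(F)cc4)ccc3c(=O)c2O)c1)c1cnc(Cl)nc1Cl` differs from compound 3 at the same carbonyl carbon: 2,4-dichloropyrimidin-5-yl in place of 6-chloropyridin-3-yl on a carbonyl carbon. The measured steps at this carbonyl carbon bear on it: a 3.6-fold lower number from compound 1 to compound 2 (0.56 log units; beyond the scatter) and a 2.4-fold lower number from compound 1 to compound 3 (0.39 log units; beyond the scatter) lowered the number modestly, while a 1.5-fold higher number from compound 2 to compound 3 (0.18 log units; within the scatter) stayed within the scatter. At most a modest step is expected, with no firm direction, so the estimated step is a 1.2-fold lower number from compound 3 to compound 4 (0.08 log units; within the scatter). Compound 4 is therefore expected to give 3000 nM in this assay, in a range from 1200 nM to 8000 nM.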

Compound 4, half-maximal inhibitory concentration: > 100000 nM
Compound 4 ended at the assay's limit; the forecaster's own chance of this, stated with the estimate: 5%; at least 33-fold (1.52 log units) between middle value and limit.
By their numbers in this assay, from the lowest: compounds 2 and 3 (each within the scatter of the next); then compound 1. At a limit, above all of these: compound 4.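

The value of compound 4 in this assay is a limit and not a number: the limit of > 100000 nM in this assay, at which 1 of the 4 values shown sits. Earlier swaps at this carbonyl carbon gave modest steps or none beyond the scatter, whereas 2,4-dichloropyrimidin-5-yl gives large ones: an at least 27-fold higher number from compound 3 to compound 4 (1.44 log units; beyond the scatter), an at least 41-fold higher number from compound 2 to compound 4 (1.62 log units; beyond the scatter) and an at least 11-fold higher number from compound 1 to compound 4 (1.06 log units; beyond the scatter). The position is thus far more sensitive to the aryl group it carries than compounds 1, 2 and 3 alone revealed.

The change from 6-chloropyridin-3-yl to 2,4-dichloropyrimidin-5-yl alters ring nitrogen and chlorine together, so the compounds shown cannot tell which of the two goes with the large step. They also leave open how a pyrimidin-5-yl ring without chlorine, or one bearing an amine in place of chlorine, would read in this assay.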